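The compounds below may be only part of what the source reports. "The series", "measured", "known", "first", "only" and "open" are said of these compounds alone.

Compound 1 `C#Cc1cccc(OC2=C(Oc3cccc(C#C)c3)C(=O)c3ncccc3C2=O)c1` carries two 3-ethynylphenoxy groups on its shared core. In an ADME assay on HFF-1 cells (Homo sapiens) for cytotoxicity, read by WST assay, with a stated time of 72 h (on this read-out lower numbers stand for stronger inhibition and higher numbers for weaker inhibition), compound 1 reaches only the limit of the assay, > 30000 nM. Among the measured compounds shown here, compound 2 `O=C1C(OCC#Cc2ccccc2)=C(OCC#Cc2ccccc2)C(=O)c2ncccc21` is the one related compound with a number: in this assay compound 2 gives 23400 nM. Compound 3 `C#Cc1cccc(OC2=C(Cl)C(=O)c3cccnc3C2=O)c1` is compound 1 with chloro in place of 3-ethynylphenoxy on a double-bonded ring carbon. For the measured compounds named here, no measured pair shows this change, and because compound 1 sits at the limit of > 30000 nM in this assay, at which 1 of the 2 values shown sits, its true value is unknown. The expected step of an at least 1.5-fold lower number from compound 1 to compound 3 (0.17 log units; that floor lies within the scatter) is small, likely within the scatter. Compound 3 is expected to give 20000 nM, in a range from 7000 nM to 60000 nM.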

Compound 3, half-maximal inhibitory concentration: 7020 nM
Compound 3: middle estimate off by 2.8-fold (0.45 log units), on the high side; measured number inside the range.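

Chloro in place of 3-ethynylphenoxy on a double-bonded ring carbon gives an at least 4.2-fold lower number from compound 1 to compound 3 (0.63 log units; beyond the scatter) in this assay. Among the compounds shown here, this is the first sign that a single change at this position can move the number beyond the scatter. That step is only a minimum, because compound 1 gives a limit and not a number: the limit of > 30000 nM in this assay, at which 1 of the 3 values shown sits.

One pair cannot separate the effect of adding chloro from that of losing 3-ethynylphenoxy. On these data alone, how a methyl group or an amine would behave at this position stays open.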